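Methyl on the Outer Ring: Cytotoxicity in Macrophages

This account rests on a few compounds, and the source may have more. Where it says the series, first, only, none or still open, it means among the compounds named here.

Measured so far:
Compound 1 `OCCCCCC(O)c1ccc(-c2ccc(F)cc2)cc1`: 18000 nM
Compound 2 `Cc1cc(F)ccc1-c1ccc(C(O)CCCCCO)cc1`: 20000 nM
Compound 3 `O=C(CCCCCO)c1ccc(-c2ccccc2)cc1`: 22000 nM

Of the compounds shown here, three have been tested in a functional assay on J774 cells (Mus musculus) for cytotoxicity, read by resazurin assay; on this read-out higher numbers stand for weaker inhibition and lower numbers for stronger inhibition. Compound 1 and compound 2 share one core; compound 3 has a different core, and the difference between the two cores is not broken down here. Among the measured values, compound 3 gives the highest number in this assay, but its gaps to compound 2 and to compound 1 are both within the scatter, so no order among the three can be claimed.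

One change has been made on a measured pair: from compound 1 to compound 2, (methyl in place of hydrogen on an aromatic carbon), and the step was a 1.1-fold higher number from compound 1 to compound 2 (0.05 log units; within the scatter). Compound 4 `Cc1cccc(-c2ccc(C(=O)CCCCCO)cc2)c1` carries the same kind of change on the core of compound 3: methyl in place of hydrogen on an aromatic carbon. The surroundings of the place differ, though. In compound 2 the methyl sits ortho to a large group and meta to a fluoro group; in compound 4 it sits meta to a large group, with no fluoro group on that ring.

Given that the one measured step of this kind stayed within the scatter, compound 4 is expected to give a number close to that of compound 3 in this assay, a step of a 1.0-fold higher number from compound 3 to compound 4 (0.02 log units; within the scatter). The estimate for compound 4 is 23000 nM, with a range from 12000 nM to 45000 nM.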

Compound 4, half-maximal inhibitory concentration: 100000 nM
Estimate against measurement, compound 4: 4.3-fold (0.64 log units) below; measured number outside the range, above it.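

In this assay, methyl in place of hydrogen on an aromatic carbon, here phenyl to 3-methylphenyl, gave a 4.5-fold higher number from compound 3 to compound 4 (0.66 log units; beyond the scatter), so on the core of compound 3 this small change goes with weaker inhibition of the cells. Set beside the earlier pair, the same change did not carry over from one core to the other with the same size: the same change on two cores in this assay, a 1.1-fold higher number (0.05 log units; within the scatter) from compound 1 to compound 2 and a 4.5-fold higher number (0.66 log units; beyond the scatter) from compound 3 to compound 4, 4.1-fold (0.61 log units) apart, beyond the scatter of two such steps This does not show why the two steps differ, since the pairs differ in more than the core: the methyl stands in different surroundings in each, and only compound 1 and compound 2 carry a fluoro group, so a single pair on each side cannot separate these differences or show how the change would behave on a further core.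

The compounds shown leave open whether a chloro or methoxy group, meta to the same large group on the core of compound 3, would give a step of similar size to that of methyl. They also leave open whether the methyl step would hold up with a fluoro group on the same ring, or with a longer chain or a carboxylic acid on the other end of the molecule.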